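Thiazolyl isomers on the shared core: compound 3 to compound 4

The compounds below may be only part of what the source reports. "The series", "measured", "known", "first", "only" and "open" are said of these compounds alone.

In an in vitro ADME assay on microsomes from liver (Homo sapiens) for metabolic stability (a higher number here means faster removal of the compound, a lower number slower removal), compound 1 `O=C(COCc1ccccn1)N1CCN(c2ccc(Cl)cc2Cl)CC1` gives 94 mL.min-1.g-1, compound 2 `O=C(COCc1cscn1)N1CCN(c2ccc(Cl)cc2Cl)CC1` gives 62 mL.min-1.g-1 and compound 3 `O=C(COCc1cncs1)N1CCN(c2ccc(Cl)cc2Cl)CC1` gives 73 mL.min-1.g-1. All three lie within the scatter of one another, so compound 3 holds no distinct place among them. Compound 4 `O=C(COCc1nccs1)N1CCN(c2ccc(Cl)cc2Cl)CC1` is reached through (1,3-thiazol-2-yl in place of 1,3-thiazol-5-yl on a saturated chain carbon bound to an oxygen on a saturated carbon), with 1,3-thiazol-2-yl in place of 1,3-thiazol-5-yl. Within the data shown here, the closest precedent is a 1.2-fold higher number from compound 2 to compound 3 (0.07 log units; within the scatter), also an exchange of one 1,3-thiazolyl isomer for another. The steps of a 1.5-fold lower number from compound 1 to compound 2 (0.18 log units; within the scatter) and a 1.3-fold lower number from compound 1 to compound 3 (0.11 log units; within the scatter) are similarly small. No change beyond the scatter is therefore expected in this assay. The expected step is a 1.0-fold lower number from compound 3 to compound 4 (0.02 log units; within the scatter). Compound 4 is estimated at 70 mL.min-1.g-1, with an expected range of 40 mL.min-1.g-1 to 120 mL.min-1.g-1.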

Compound 4, intrinsic clearance in microsomes: 80 mL.min-1.g-1
For compound 4 the middle estimate is 1.1-fold (0.06 log units) below the measured one; measured number inside the range.
By their numbers in this assay, from the lowest: compounds 2, 3, 4 and 1 (each within the scatter of the next).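

In this assay, 1,3-thiazol-2-yl in place of 1,3-thiazol-5-yl gives (a 1.1-fold higher number from compound 3 to compound 4 (0.04 log units; within the scatter)), and in place of 1,3-thiazol-4-yl it gives (a 1.3-fold higher number from compound 2 to compound 4 (0.11 log units; within the scatter)), so the three thiazolyl isomers stay within the scatter of one another. In place of pyridin-2-yl it gives (a 1.2-fold lower number from compound 1 to compound 4 (0.07 log units; within the scatter)), so no group among the four separates at this position, on a saturated chain carbon bound to an oxygen on a saturated carbon. No supporting data explain why these numbers stay together.

On these data alone, whether a phenyl group, an amine, a carboxylic acid or a longer chain in this place would give a step beyond the scatter remains open.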